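A few compounds are considered here, and "the series" means these few. Any claim that something is new, unique, unknown or untested is made for them only; others in the source may bear on it.

Measured in a functional assay on SF-268 cells (Homo sapiens) for antiproliferative activity, read by sulforhodamine B assay, with a stated time of 72 h; a higher number here means a weaker inhibitor, a lower number a stronger inhibitor:
- compound 1 `O=C1CS/C(=N/Nc2nncc3ccccc23)N1c1ccccc1`: 7 nM
- compound 2 `C(=C/c1ccccc1)\C(=N\Nc1nncc2ccccc12)c1ccccc1`: 3.2 nM
- compound 3 `S=C(NNc1nncc2ccccc12)Nc1ccccc1`: 57 nM

Of these three, compound 2 has the lowest number, so it is the strongest inhibitor in this assay. Compound 4 `Clc1ccc(C(/C=C/c2ccccc2)=N\Nc2nncc3ccccc23)cc1` differs from it in one place: chloro in place of hydrogen on an aromatic carbon. One phenyl becomes 4-chlorophenyl, with chloro in place of hydrogen on an aromatic carbon. Going by the values given here, no measured pair shows this change, so the expectation rests only on compound 2 at 3.2 nM. The expected change is small and slightly towards weaker inhibition, probably not beyond the usual scatter: a 1.3-fold higher number from compound 2 to compound 4 (0.10 log units; within the scatter). For compound 4 the estimated value is 4 nM, with an expected range of 1.2 nM to 14 nM.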

Compound 4, half-maximal inhibitory concentration: 6.3 nM
Compound 4: the middle estimate sits 1.6-fold (0.20 log units) below what was measured; measured number inside the range.
By their numbers in this assay, from the lowest: compounds 2, 4 and 1 (each within the scatter of the next, the first and the last beyond it); then compound 3.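

In this assay, chloro in place of hydrogen on this aromatic carbon, para to a large group, gives a 2.0-fold higher number from compound 2 to compound 4 (0.29 log units; within the scatter), so this step cannot be told apart from repeat-measurement scatter. Going by these compounds alone, the earlier compounds all carried unsubstituted phenyl rings, and this is the first sign that the position can hold a substituent while the number stays in the low range. Nothing measured here offers an explanation for this result. Going by these compounds, it remains open whether an amine, a methoxy group or a carboxylic acid at this place would behave the same way, and whether chloro on the other phenyl ring would.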